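This account rests on a few compounds, and the source may have more. Where it says the series, first, only, none or still open, it means among the compounds named here.

Two compounds share a core and differ only in the group attached to the sulfonyl sulfur. In a functional assay on MIA PaCa-2 cells (Homo sapiens) for inhibition, read by MTT assay, with a stated time of 72 h (on this read-out higher numbers stand for weaker inhibition of growth and lower numbers for stronger inhibition of growth), compound 1 `O=S(=O)(NCCCCCCNCc1ccc(Br)cc1)c1ccc(C(F)(F)F)cc1` gives 3830 nM. Compound 2 `O=S(=O)(NCCCCCCNCc1ccc(Br)cc1)c1ccc2c(c1)OCC2` gives 13000 nM in this assay, the higher of the two numbers, and its gap to compound 1 lies beyond the usual scatter of repeated measurements. Compound 3 `CC(C)c1ccc(S(=O)(=O)NCCCCCCNCc2ccc(Br)cc2)cc1` has not yet been measured; it differs from compound 2 by a group of 9 heavy atoms (9 carbon; one six-membered aromatic ring of carbon only) in place of a group of 9 heavy atoms (8 carbon, 1 oxygen; one five-membered non-aromatic ring with 1 hetero atom, one six-membered aromatic ring of carbon only), on a sulfonyl sulfur. Among the measured compounds shown here, no measured pair shows exactly this exchange, so the expectation rests on the two numbers in hand. Because compound 1 gives 3830 nM with a different group on the same sulfonyl sulfur, the step of a 2.4-fold lower number from compound 2 to compound 3 (0.37 log units; beyond the scatter) is expected to move toward stronger inhibition of growth, by a modest amount rather than a large one. Compound 3 is estimated at 5500 nM, within a range from 2000 nM to 15000 nM.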

Compound 3, concentration for 50% growth inhibition: 5730 nM
For compound 3 the middle estimate is 1.0-fold (0.02 log units) below the measured one, and the stated range covers the measured number.
By their numbers in this assay, from the lowest: compounds 1 and 3 (each within the scatter of the next); then compound 2.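

In this assay the step to 4-isopropylphenyl on the sulfonyl sulfur gives a 2.3-fold lower number from compound 2 to compound 3 (0.36 log units; beyond the scatter) and leaves the count of 9 heavy atoms unchanged, so at this position the number can move while that count stays the same. Isopropyl in place of trifluoromethyl on an aromatic carbon gives a 1.5-fold higher number from compound 1 to compound 3 (0.17 log units; within the scatter) and so separates these two groups by no more than repeated measurements would. No measurement here explains either result.

The compounds shown leave open how an amine or a carboxylic acid on that aromatic ring would affect the number. They also leave open whether a longer chain in the shared core would change it.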